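Propyl to tert-butyl on a shared fused core

The compounds below may be only part of what the source reports. "The series", "measured", "known", "first", "only" and "open" are said of these compounds alone.

compound 1 `CC(C)(C)c1nc(Br)c2cnnc(O)n12` — 19000 nM
compound 2 `CCCc1ncc2cnnc(O)n12` — > 48000 nM

Of the compounds shown here, two have been measured in a functional assay for inhibition, with Homo sapiens as the target; on this read-out lower numbers stand for stronger inhibition and higher numbers for weaker inhibition. Compound 1 `CC(C)(C)c1nc(Br)c2cnnc(O)n12` carries a bromine and a tert-butyl and gives 19000 nM. Compound 2 `CCCc1ncc2cnnc(O)n12` reached only the limit of the assay, > 48000 nM, so no number is known for it. One of the two values shown sits at that limit (the limit of > 48000 nM in this assay, at which 1 of the 2 values shown sits). Compound 3 `CC(C)(C)c1ncc2cnnc(O)n12` is the unmeasured partner of compound 2: tert-butyl in place of propyl on an aromatic carbon. Within the data shown here, no measured pair isolates this change, so nothing shows how large a step it brings in this assay; the expected step of an at least 1.2-fold lower number from compound 2 to compound 3 (0.07 log units; that floor lies within the scatter) is taken as none beyond the scatter. Compound 3 is therefore estimated at 40000 nM, within 15000 nM to 120000 nM, with a fair chance that the assay again reports only a limit.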

Compound 3, half-maximal inhibitory concentration: > 48000 nM
Compound 3: a limit, no number (the forecaster's own chance of this, stated with the estimate: 55%); at least 1.2-fold (0.07 log units) between middle value and limit.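

With hydrogen in place of bromo on an aromatic carbon, this assay shows an at least 2.5-fold higher number from compound 1 to compound 3 (0.40 log units; beyond the scatter). Among these compounds, this is the only step that can be read, and it links the bromine of compound 1 to stronger inhibition, which the two earlier compounds could not show because they differ in two places. The step for tert-butyl in place of propyl cannot be read, because compound 2 and compound 3 both give only a limit and no number: the limit of > 48000 nM in this assay, at which 2 of the 3 values shown sit.

As far as these compounds go, it remains open whether chlorine or an amine in the place of the bromine would keep, exceed or lose the inhibition seen for compound 1. From the compounds shown here alone, it is also open whether propyl in place of tert-butyl would change the number once the bromine is present.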